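Indene for chlorinated benzocyclobutene on the ethyl chain

The compounds below may be only part of what the source reports. "The series", "measured", "known", "first", "only" and "open" are said of these compounds alone.

Three members of the series have been examined in a functional assay on the whole organism for agonist activity, with Rattus norvegicus as the target; a lower number here means that less compound is needed, a higher number that more compound is needed for the effect. Among the measured compounds shown here, compound 1 `Clc1cccc2c1CC2CCN1CCN(c2cccc3c2OCCO3)CC1` is the only one with a number, giving 40 mg/kg. Compound 2 `c1ccc2c(c1)CC2CN1CCN(c2cccc3c2OCCCO3)CC1` reaches only a limit of the assay, > 10 mg/kg. Compound 3 `c1ccc2c(c1)CCCCC2CCN1CCN(c2cccc3c2OCCO3)CC1` likewise stops at a limit, > 10 mg/kg. For the measured compounds named here, two of the three results therefore sit at the limit of > 10 mg/kg in this assay, at which 2 of the 3 values shown sit, and the one number from compound 1 lies above that point, so no step between measured compounds can be drawn.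

Compound 4 `C1=C(CCN2CCN(c3cccc4c3OCCO4)CC2)Cc2ccccc21` is not yet measured. It differs from compound 1 at one place: a group of 9 heavy atoms (9 carbon; one five-membered non-aromatic ring of carbon only, one six-membered aromatic ring of carbon only) in place of a group of 9 heavy atoms (8 carbon, 1 chlorine; one four-membered non-aromatic ring of carbon only, one six-membered aromatic ring of carbon only), on a saturated chain carbon, two bonds along the chain from an amine nitrogen in a ring. The ethyl chain to the ring amine and the shared core are kept; the bicyclic group at its end changes ring size, loses the chlorine and gains a double bond outside the aromatic rings.

Going by the values given here, with no measured step to lean on, the expectation for the change from compound 1 to compound 4 is a move within the scatter, no change at the digits printed from compound 1 to compound 4 (within the scatter), in no particular direction. Compound 4 is accordingly estimated at 40 mg/kg, with a range from 10 mg/kg to 160 mg/kg. The lower end of that range lies in the region where the limit seen for compounds 2 and 3 applies, so a limit rather than a number remains a real possibility.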

Compound 4, minimum effective dose: 10 mg/kg
Compound 4: the middle estimate sits 4.0-fold (0.60 log units) above what was measured, within the range that was stated.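

At this place, on a saturated chain carbon, two bonds along the chain from an amine nitrogen in a ring, the group at the end of the ethyl chain now proves able to shift the minimum effective dose in this assay, with the exchange giving a 4.0-fold lower number from compound 1 to compound 4 (0.60 log units; beyond the scatter). The exchange changes ring size, removes the chlorine and adds a double bond outside the aromatic rings, so this single step cannot divide its size among those three differences. Compounds 2 and 3 each remain a limit of the assay and not a number, and no step to either can be read: the limit of > 10 mg/kg in this assay, at which 2 of the 4 values shown sit.

It remains open whether the lower number in compound 4 follows the five-membered ring, the absence of chlorine or the double bond, since no compound shown separates them. Also open, as far as these compounds go, is how a fluorine or a methoxy group on the six-membered aromatic ring of compound 4, or a propyl chain in place of the ethyl chain, would read in this assay.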